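A few compounds are considered here, and "the series" means these few. Any claim that something is new, unique, unknown or untested is made for them only; others in the source may bear on it.

Working notes on the series. In an ADME assay on liver for metabolic stability, with Liver microsome (Homo sapiens) as the target, using microsomes (on this read-out lower numbers stand for slow clearance and higher numbers for fast clearance), compound 1 (`COc1ccc(C(=O)Nc2[nH]nc(-c3ccccn3)c2C2CC2)cc1`) reads 12.8 mL.min-1.g-1 and compound 2 (`N#Cc1ccc(OC2CCN(C(=O)Nc3cc(-c4ccccn4)n[nH]3)CC2)cc1`) reads 14.7 mL.min-1.g-1 while compound 3 (`O=C(NCc1cccc(Cl)c1)Nc1cc(-c2ccccn2)n[nH]1`) reads 184 mL.min-1.g-1 on the same scale. Compound 2 stands level with compound 1 within the scatter, and compound 3 lies well above compound 2, beyond the scatter.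

Compound 4 (`O=C(Nc1cc(-c2ccccn2)n[nH]1)N1CCC(c2ccccc2)CC1`) has not yet been measured. Its difference from compound 2 is phenyl in place of 4-cyanophenoxy on a saturated ring carbon. Among the measured compounds shown here, no two measured compounds differ in one place, so no measured step shows what this kind of change does in this assay. The expectation therefore rests on the spread alone: compound 2 at 14.7 mL.min-1.g-1 is the starting point, and compound 3 at 184 mL.min-1.g-1 shows how far numbers in this series can reach. A modest rise near the edge of the scatter is expected, with low confidence. The expected change is a 2.0-fold higher number from compound 2 to compound 4 (0.31 log units; beyond the scatter) as a best estimate. For compound 4 the estimated value is 30 mL.min-1.g-1 with an expected range from 11 mL.min-1.g-1 to 90 mL.min-1.g-1 in this read-out.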

Compound 4, intrinsic clearance in microsomes: 15.3 mL.min-1.g-1
Compound 4: middle estimate off by 2.0-fold (0.29 log units), on the high side; the measured number falls inside the stated range.
By their numbers in this assay, from the lowest: compounds 1, 2 and 4 (each within the scatter of the next); then compound 3.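

In this assay, among the compounds shown here, the first step that can be read at this position is a 1.0-fold higher number from compound 2 to compound 4 (0.02 log units; within the scatter). With phenyl in place of 4-cyanophenoxy on this saturated ring carbon, the group that enters carries no nitrile, no oxygen and no hydrogen-bond acceptors, yet the two compounds stand level, so this pair gives no sign that the read-out depends on those features of the group that leaves. No measurement at hand gives a reason for this level standing.

From the compounds shown here alone, what an amine, a carboxylic acid or a longer chain on the same ring carbon would give remains open. A single pair also cannot show whether phenyl and 4-cyanophenoxy would stand level on a different core.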